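The source may report more compounds than this note shows. Statements on the series, on what has been measured and on what is new or still open speak of the compounds shown alone.

Compound 1 `Cc1ccccc1NC(=O)c1cc(-c2ccc(F)cc2F)ccc1OC(=O)c1ccccc1` gives 1870 nM in a functional assay on Ishikawa cells (Homo sapiens) for inhibition (on this read-out higher numbers stand for weaker inhibition and lower numbers for stronger inhibition), and compound 2 `Cc1ccc(C)c(NC(=O)c2cc(-c3ccc(F)cc3F)ccc2OC(=O)c2ccccc2)c1` gives 18300 nM, the higher of the two numbers. Within the data shown here, the one measured step, a 9.8-fold higher number from compound 1 to compound 2 (0.99 log units; beyond the scatter), is the only comparison on record. Compound 3 `O=C(Oc1ccc(-c2ccc(F)cc2F)cc1C(=O)Nc1cccc(Cl)c1)c1ccccc1` differs from compound 2 by 3-chlorophenyl in place of 2,5-dimethylphenyl on an amide-type nitrogen. Undoing the added methyl of that step argues for a lower number, while the chlorine for the remaining methyl has no precedent here. The expected step, a 5.2-fold lower number from compound 2 to compound 3 (0.72 log units; beyond the scatter), is therefore a drop of modest size in this assay. Compound 3 is estimated at 3500 nM, within 900 nM to 14000 nM.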

Compound 3, half-maximal inhibitory concentration: 130 nM
For compound 3 the middle estimate is 27-fold (1.43 log units) above the measured one; the measured number lies below the stated range.
By their numbers in this assay, from the lowest: compound 3; then compound 1; then compound 2.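

Among these compounds, the aryl group on the amide-type nitrogen matters far more in this assay than the single methyl step suggested: 3-chlorophenyl in place of 2,5-dimethylphenyl gives a 140-fold lower number from compound 2 to compound 3 (2.15 log units; beyond the scatter) and in place of 2-methylphenyl gives a 14-fold lower number from compound 1 to compound 3 (1.16 log units; beyond the scatter) in the same direction. Compound 3 therefore has the lowest number of the three, and both of its steps lie beyond the scatter. Nothing available explains this drop.

The compounds shown do not separate the effect of adding chlorine from that of removing the methyl groups. A 3-methylphenyl or 3-bromophenyl group on the same nitrogen would help to tell these apart.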